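This account rests on a few compounds, and the source may have more. Where it says the series, first, only, none or still open, it means among the compounds named here.

The study asks how strongly a small set of compounds kill cultured cells, read in a functional assay on MOLT-4 cells (Homo sapiens) for cytotoxicity, read by sulforhodamine B assay, with a stated time of 48 h; on this read-out higher numbers stand for lower toxicity in this test and lower numbers for higher toxicity in this test. Compound 1, `ClCc1ccc(Cn2cnc3c(Cl)ncnc32)cc1`, is the starting point. In this assay compound 1 gives > 100000 nM, which is a limit of the test rather than a measured number. Compound 2, `ClCc1ccc(Cn2cnc3nc(Cl)nc(Cl)c32)cc1`, carries two chloro groups on the shared core. In this assay compound 2 gives > 100000 nM, again a limit. Compound 3, `ClCc1cccc(Cn2cnc3c(Cl)nc(Cl)nc32)c1`, is another member with two chloro groups. In this assay compound 3 gives > 100000 nM, also a limit. Every value shown therefore sits at the limit of > 100000 nM in this assay, at which 3 of the 3 values shown sit: none of the compounds reached a measurable value within the tested range, and compound 1 stands level with the other two rather than apart from them.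

Compound 4, `ClCc1ccc(Cn2cnc3c(Cl)nc(Cl)nc32)cc1`, has not yet been tested. It differs from compound 1 in one place: chloro in place of hydrogen on an aromatic carbon. Within the data shown here, no step between two measured compounds is available to say what this added chloro group does. Among the measured compounds shown here, compound 2 and compound 3 both hold two chloro groups and both reach only the limit, and that is the only guide. It points to compound 4 staying at the limit as well, so the step that the limit leaves unreadable from compound 1 to compound 4 is expected to be nothing beyond the scatter. Compound 4 is estimated at 150000 nM, within 50000 nM and 500000 nM.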

Compound 4, concentration lethal to 50% of the cells: 72400 nM
Compound 4: the middle estimate sits 2.1-fold (0.32 log units) above what was measured, within the range that was stated.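

Among these compounds, with chloro in place of hydrogen on an aromatic carbon between two ring nitrogen atoms, compound 4 gives 72400 nM in this assay, the first real number in this set rather than a limit. This change comes with an at least 1.3-fold lower number from compound 1 to compound 4 (0.14 log units; that floor lies within the scatter), so the true step may be larger, but the part that can be read does not go beyond the scatter, and the data cannot yet show that this chloro group changes toxicity in this test. The step stays a floor rather than a measured size because compound 1 gives only a limit, not a number: the limit of > 100000 nM in this assay, at which 3 of the 4 values shown sit.

On these data alone, what an amine, a methoxy group or a bromo group at this same position would give in this assay stays open, as does whether any effect here belongs to chloro in particular or to any group larger than hydrogen. As far as these compounds go, the true size of the step from hydrogen to chloro also remains open, along with whether this position matters more than the other places on the shared core that carry chloro groups.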